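This account rests on a few compounds, and the source may have more. Where it says the series, first, only, none or still open, it means among the compounds named here.

In a functional assay on QGY cells (Homo sapiens) for cytotoxicity, read by MTT assay, with a stated time of 48 h (on this read-out higher numbers stand for weaker inhibition and lower numbers for stronger inhibition), three compounds sharing one core have been measured. Compound 1 `COc1cc([C@@H]2C[C@]2(CO)C(=O)Nc2ccccc2Cl)cc(OC)c1OC` gives 15700 nM. Compound 2 `COc1cc([C@H]2C[C@@]2(CO)C(=O)Nc2ccccc2Cl)cc(OC)c1OC`, its mirror image, reaches only an assay limit of > 100000 nM. Compound 3 `CCOC(=O)[C@@]1(C(=O)Nc2ccccc2Cl)C[C@H]1c1cc(OC)c(OC)c(OC)c1` gives 34300 nM, a higher number than compound 1, by more than the scatter. Compound 4 `COc1cc([C@@H]2C[C@@]2(CO)C(=O)Nc2ccccc2Cl)cc(OC)c1OC` follows from compound 3 through (hydroxymethyl in place of ethoxycarbonyl on a saturated ring carbon). Going by the values given here, no measured step makes this exchange. Among the compounds with values here, the only measured step is an at least 6.3-fold higher number from compound 1 to compound 2 (0.80 log units; beyond the scatter), and it comes with the fact that compounds 1 and 2 differ only in the configuration as drawn, so the same hydroxymethyl can go with very different numbers and no direction is secure. The expected result is a 1.1-fold lower number from compound 3 to compound 4 (0.06 log units; within the scatter), with no shift beyond the scatter expected. For compound 4, the estimated value is 30000 nM, with an expected range from 9000 nM to 100000 nM.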

Compound 4, half-maximal inhibitory concentration: 24500 nM
Estimate against measurement, compound 4: 1.2-fold (0.09 log units) above, within the range that was stated.
By their numbers in this assay, from the lowest: compounds 1, 4 and 3 (each within the scatter of the next, the first and the last beyond it). At a limit, above all of these: compound 2.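

In this assay, hydroxymethyl in place of ethoxycarbonyl on this saturated ring carbon gives a 1.4-fold lower number from compound 3 to compound 4 (0.15 log units; within the scatter), so this exchange shows no shift beyond the scatter. A single differing stereocentre gives an at least 4.0-fold lower number from compound 2 to compound 4 (0.61 log units; beyond the scatter), yet a single differing stereocentre also gives a 1.6-fold higher number from compound 1 to compound 4 (0.19 log units; within the scatter), so configuration matters in one of these steps and not measurably in the other. The > 100000 nM of compound 2 is an assay limit.

On these data alone, whether an amine or a carboxylic acid on this ring carbon would move the number beyond the scatter stays open. So does the reading of the mirror image of compound 4.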